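Hydroxy to Chloromethyl: What to Expect of Compound 3

The source may report more compounds than this note shows. Statements on the series, on what has been measured and on what is new or still open speak of the compounds shown alone.

Going by the values given here, in a functional assay on HCT-116 cells (Homo sapiens) for inhibition, read by MTT assay, with a stated time of 48 h (on this read-out higher numbers stand for weaker inhibition and lower numbers for stronger inhibition), compound 2 (`COc1ccc(CN(C(=O)CO)c2cc(OC)c(OC)c(OC)c2)cc1O`) gives 520 nM and stands highest of the two numbers so far, with compound 1 (`CCCCC(=O)N(Cc1ccc(OC)c(O)c1)c1cc(OC)c(OC)c(OC)c1`) at 170 nM on this read-out. Compound 3 (`COc1ccc(CN(C(=O)CCCl)c2cc(OC)c(OC)c(OC)c2)cc1O`) carries chloromethyl in place of hydroxy on a saturated chain carbon bound to a carbonyl carbon. Compound 3 likewise lacks the hydroxy, so on the evidence of a 3.1-fold higher number from compound 1 to compound 2 (0.49 log units; beyond the scatter) for hydroxy in place of propyl, a modest step beyond the scatter, a similar or smaller step to a lower number is expected in this assay here. The expected change is a 2.4-fold lower number from compound 2 to compound 3 (0.37 log units; beyond the scatter) in this estimate. Compound 3 is thus estimated at 220 nM with a range from 80 nM to 600 nM in all.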

Compound 3, half-maximal inhibitory concentration: 150 nM
Estimate against measurement, compound 3: 1.5-fold (0.17 log units) above; measured number inside the range.
By their numbers in this assay, from the lowest: compounds 3 and 1 (each within the scatter of the next); then compound 2.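

In this assay the swap of hydroxy for chloromethyl gives a 3.5-fold lower number from compound 2 to compound 3 (0.54 log units; beyond the scatter) and so shows that this position tolerates more than one chain end without the higher number seen with hydroxy. Chloro in place of ethyl gives a 1.1-fold lower number from compound 1 to compound 3 (0.05 log units; within the scatter) and so makes no readable difference here. Nothing measured on these compounds explains either result.

The compounds shown leave open whether hydroxy alone sets the higher number apart. An amine, a carboxylic acid or a longer chain at this position could show how far that holds.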